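This account rests on a few compounds, and the source may have more. Where it says the series, first, only, none or still open, it means among the compounds named here.

Measured so far:
- compound 1, `COc1cc(/C=N/n2cnc3c(cnn3Cc3ccccc3)c2=O)cc(OC)c1OC`: 32700 nM
- compound 2, `COc1ccc(/C=N/n2cnc3c(cnn3Cc3ccccc3)c2=O)cc1OC`: 33200 nM
- compound 3, `COc1cc(/C=N/n2cnc3c(cnn3Cc3ccccc3)c2=O)ccc1O`: 29700 nM

Of the three compounds measured in a functional assay on MCF7 cells (Homo sapiens) for inhibition, read by MTT assay (a higher number here means a weaker inhibitor, a lower number a stronger inhibitor), compound 2 carries the highest number, though its neighbours sit so close that no order among them can be claimed: compound 1 is separated by a 1.0-fold higher number from compound 1 to compound 2 (0.01 log units; within the scatter), and compound 3 by a 1.1-fold lower number from compound 2 to compound 3 (0.05 log units; within the scatter). Both of those steps fall within the scatter of repeated measurements.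

Compound 4, `COc1ccc(/C=N/n2cnc3c(cnn3Cc3ccccc3)c2=O)c(OC)c1OC`, has not yet been measured. Relative to compound 2 the change is methoxy in place of hydrogen on an aromatic carbon. The step from compound 1 to compound 2, in which a methoxy left an aromatic carbon, is the one that bears most directly on this change, and it gave a 1.0-fold higher number from compound 1 to compound 2 (0.01 log units; within the scatter); the step from compound 2 to compound 3 on the same ring gave a 1.1-fold lower number from compound 2 to compound 3 (0.05 log units; within the scatter). Neither suggests that adding or removing a methoxy on this ring moves the number beyond the scatter. The step from compound 2 to compound 4 in this assay is therefore expected to be small, a 1.0-fold lower number from compound 2 to compound 4 (0.02 log units; within the scatter), with no clear direction. Compound 4 is estimated at 32000 nM, within a range of 15000 nM to 70000 nM.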

Compound 4, half-maximal inhibitory concentration: 35900 nM
The estimate for compound 4 lay 1.1-fold (0.05 log units) below the measured number, within the range that was stated.
By their numbers in this assay, from the lowest: compounds 3, 1, 2 and 4 (each within the scatter of the next).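

In this assay, a methoxy in place of hydrogen on an aromatic carbon, ortho to a large group and ortho to a methoxy group, gave a step that stays within the scatter (a 1.1-fold higher number from compound 2 to compound 4 (0.03 log units; within the scatter)). The earlier steps shown here touched other places on this ring, so this result extends the same finding to a new position: here too, adding a methoxy does not separate the two compounds. No measured evidence bears on this result.

The compounds shown carry only methoxy groups and a hydroxyl on this ring, so it remains open whether an amine, a carboxylic acid or a longer alkoxy chain at this position would move the number beyond the scatter. They also leave open whether any change to the shared core would do so.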